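The source may report more compounds than this note shows. Statements on the series, on what has been measured and on what is new or still open speak of the compounds shown alone.

Compound 2 `CN(C)CCn1cnnc1-c1cc(Oc2ccc(NC(=O)N/N=C/c3c[nH]c4ccccc34)cc2F)ccn1` gives 820 nM in a functional assay on A549 cells (Homo sapiens) for cytotoxicity, read by MTT assay, with a stated time of 72 h; a higher number here means a weaker inhibitor, a lower number a stronger inhibitor. Among the compounds with values here, it is one of only two measured compounds, the other being compound 1 `CN(C)CCn1cnnc1-c1cc(Oc2ccc(NC(=O)N/N=C/c3ccc(F)cc3Cl)cc2F)ccn1`, which gives 1120 nM in this assay. Compound 2 stands level with compound 1 on these numbers, since the step of a 1.4-fold lower number from compound 1 to compound 2 (0.14 log units; within the scatter) is within the scatter; nothing separates the two beyond the noise of the measurement.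

Compound 3 `CN(C)CCn1cnnc1-c1cc(Oc2ccc(NC(=O)N/N=C/c3ccc(F)cc3)cc2F)ccn1` has not yet been measured in this assay. It differs from compound 2 in one place: 4-fluorophenyl in place of 1H-indol-3-yl on a carbon with a double bond to nitrogen. Within the data shown here, the only measured step that bears on this change is the one from compound 1 to compound 2, where 2-chloro-4-fluorophenyl was replaced by 1H-indol-3-yl at the same carbon with a double bond to nitrogen, and that step, a 1.4-fold lower number from compound 1 to compound 2 (0.14 log units; within the scatter), stayed within the scatter. On this evidence a change of aryl group at that position is expected to make no step beyond the scatter, so the step of a 1.2-fold higher number from compound 2 to compound 3 (0.09 log units; within the scatter) is estimated to be small. Compound 3 is therefore expected to give about 1000 nM in this assay, with a range from 450 nM to 2300 nM.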

Compound 3, half-maximal inhibitory concentration: 1790 nM
Estimate against measurement, compound 3: 1.8-fold (0.25 log units) below, within the range that was stated.
By their numbers in this assay, from the lowest: compounds 2, 1 and 3 (each within the scatter of the next, the first and the last beyond it).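

At the carbon with a double bond to nitrogen, a change of aryl group can move the number in this assay: 4-fluorophenyl in place of 1H-indol-3-yl gives a 2.2-fold higher number from compound 2 to compound 3 (0.34 log units; beyond the scatter), a modest step but the first at this position to pass the scatter. Hydrogen in place of chloro on an aromatic carbon gives a 1.6-fold higher number from compound 1 to compound 3 (0.20 log units; within the scatter), so this change on the phenyl ring does not separate the two compounds, and the 2-chloro-4-fluorophenyl compound stands level with both of the others, while only the 1H-indol-3-yl and 4-fluorophenyl compounds stand apart. Nothing among the data given accounts for the gap between those two compounds.

The 1H-indol-3-yl group differs from 4-fluorophenyl at once in its five-membered ring, its hydrogen-bond donor and the absence of fluorine, so this single step does not show which of these differences goes with the higher number. An indol-3-yl group carrying a methyl on its ring nitrogen, or a plain phenyl or pyridyl group at the same carbon, would remain to be placed against these values.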